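The compounds below may be only part of what the source reports. "The series", "measured", "known", "first", "only" and "open" are said of these compounds alone.

In an ADME assay on microsomes from liver (Rattus norvegicus) for metabolic stability, read by LC-MS, with a stated time of 10 min, tested at 0.5 uM (on this read-out lower numbers stand for a less stable compound and higher numbers for a more stable compound), compound 1 `c1ccc2c(c1)CN[C@@H](CN(CCCN1CCNCC1)[C@H]1CCCc3cccnc31)C2` gives 100%, compound 2 `c1ccc2c(c1)CN[C@@H](CN(CC[C@@H]1CCCNC1)[C@H]1CCCc3cccnc31)C2` gives 28%, and compound 3 `CC(C)N1CCN(CCCN(C[C@H]2Cc3ccccc3CN2)[C@H]2CCCc3cccnc32)CC1` gives 4%, the lowest of the three numbers. Compound 4 `CCN1CCN(CCCN(C[C@H]2Cc3ccccc3CN2)[C@H]2CCCc3cccnc32)CC1` departs from compound 3 by hydrogen in place of methyl on a saturated chain carbon bound to an amine nitrogen in a ring and a saturated chain carbon, so that isopropyl becomes ethyl. The closest measured comparison is a number 96 percentage points lower from compound 1 to compound 3 (beyond the scatter), a large step with isopropyl in place of hydrogen on an amine nitrogen in a ring. The step of a number 24 percentage points lower from compound 2 to compound 3 (beyond the scatter) is modest and exchanges the whole side group, while a number 72 percentage points lower from compound 1 to compound 2 (beyond the scatter), though large, involves no alkyl group on that nitrogen. Among the compounds with values here, no measured compound carries ethyl. Since compound 4 keeps an alkyl group there, it is expected to stay much nearer compound 3 than compound 1. The expected change is small and upward, within the scatter: a number 6 percentage points higher from compound 3 to compound 4 (within the scatter). The estimated value for compound 4 is 10%, with an expected range from 2% to 30%.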

Compound 4, percent of the compound remaining: 1%
The estimate for compound 4 lay 9 percentage points above the measured number; measured number outside the range, below it.
By their numbers in this assay, from the lowest: compounds 4 and 3 (each within the scatter of the next); then compound 2; then compound 1.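

In this assay, within the data shown here, the change from isopropyl to ethyl leaves the number within the scatter (a number 3 percentage points lower from compound 3 to compound 4 (within the scatter)), so at this position the two alkyl groups cannot be told apart, something the earlier compounds, none of which carried ethyl, could not show. The large step on going from hydrogen to an alkyl group on that amine nitrogen in a ring is therefore not tied to isopropyl alone, as ethyl also gives a large step (a number 99 percentage points lower from compound 1 to compound 4 (beyond the scatter)), while the exchange of the whole side group from compound 2 remains modest (a number 27 percentage points lower from compound 2 to compound 4 (beyond the scatter)). Nothing at hand speaks to the reason for these numbers. On these data alone, whether a methyl group on that nitrogen would behave like ethyl and isopropyl or like hydrogen remains open. So does the effect of an acetyl group or a longer chain there.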